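Swapping a Saturated Ring for an Aromatic One

A few compounds are considered here, and "the series" means these few. Any claim that something is new, unique, unknown or untested is made for them only; others in the source may bear on it.

Of the compounds shown here, three sharing one core have been measured in a functional assay for inhibition of sodium/hydrogen exchanger (Oryctolagus cuniculus); on this read-out lower numbers stand for stronger inhibition and higher numbers for weaker inhibition. Compound 1 `CCCc1cc(C)c(C(=O)N=C(N)N)cc1S(C)(=O)=O` gives 5.7 nM. Compound 2 `Cc1cc(OC(C)(C)C)c(S(C)(=O)=O)cc1C(=O)N=C(N)N` gives 9.4 nM, and compound 3 `Cc1cc(N2CCCCC2)c(S(C)(=O)=O)cc1C(=O)N=C(N)N` gives 21 nM. Compound 3 thus stands at the highest of the three numbers: the step of a 3.7-fold higher number from compound 1 to compound 3 (0.57 log units; beyond the scatter) is modest but beyond the scatter, and so is a 2.2-fold higher number from compound 2 to compound 3 (0.35 log units; beyond the scatter), whereas a 1.6-fold higher number from compound 1 to compound 2 (0.22 log units; within the scatter) stays within the scatter.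

Compound 4 `Cc1cc(-n2ccnc2)c(S(C)(=O)=O)cc1C(=O)N=C(N)N` differs from compound 3 in one place: 1H-imidazol-1-yl in place of piperidin-1-yl on an aromatic carbon. The new group sits on an aromatic carbon ortho to a methylsulfonyl group, where the piperidin-1-yl of compound 3 stood.

Going by the values given here, no measured step carries an imidazol-1-yl group, so the two steps that bear on this change do so only indirectly. Both a 3.7-fold higher number from compound 1 to compound 3 (0.57 log units; beyond the scatter) and a 2.2-fold higher number from compound 2 to compound 3 (0.35 log units; beyond the scatter) show that placing piperidin-1-yl at this position raised the number moderately relative to the propyl or tert-butoxy alternatives. Whether a five-membered aromatic ring bearing two nitrogens behaves more like piperidin-1-yl or like the other two groups cannot be read from these data. Compound 4 is therefore expected to land near compound 3, with the step of a 1.2-fold lower number from compound 3 to compound 4 (0.07 log units; within the scatter) estimated as within or only just beyond the scatter. Compound 4 is estimated at 18 nM, with a range from 6 nM to 55 nM.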

Compound 4, half-maximal inhibitory concentration: 23 nM
The estimate for compound 4 lay 1.3-fold (0.11 log units) below the measured number; low and high end bracket the measured number.
By their numbers in this assay, from the lowest: compounds 1 and 2 (each within the scatter of the next); then compounds 3 and 4 (each within the scatter of the next).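

In this assay, the step of a 1.1-fold higher number from compound 3 to compound 4 (0.04 log units; within the scatter) shows that, at this aromatic carbon ortho to a methylsulfonyl group, the five-membered aromatic 1H-imidazol-1-yl cannot be told apart from the six-membered non-aromatic piperidin-1-yl, although the two rings differ in size, aromatic character and number of nitrogens. The other two steps, a 2.4-fold higher number from compound 2 to compound 4 (0.39 log units; beyond the scatter) and a 4.0-fold higher number from compound 1 to compound 4 (0.61 log units; beyond the scatter), are both modest and beyond the scatter, so the gap that separated piperidin-1-yl from tert-butoxy and propyl is not confined to a saturated ring and reappears with an aromatic one, giving two groups of two among these four compounds. No measurement or other information given here explains why the two rings match or why they stand apart from tert-butoxy and propyl.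

As far as these compounds go, it remains open whether a phenyl ring, attached through carbon rather than nitrogen, would stay with compound 3 and compound 4 or move toward compound 1 and compound 2. An open-chain dimethylamino group would likewise show whether a ring is needed at all for this shift, or whether an attached amine nitrogen alone goes with it.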